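From Hydroxyethyl to Benzyl on the Sulfonamide

A few compounds are considered here, and "the series" means these few. Any claim that something is new, unique, unknown or untested is made for them only; others in the source may bear on it.

Going by the values given here, in a physicochemical assay for solubility, read by HPLC, using the shake flask method, measured as kinetic solubility, with a stated time of 20 h, at pH 6.5, tested at 200 uM (a higher number here means a more soluble compound, a lower number a less soluble compound), compound 3 (`O=S(=O)(NCCO)c1cccc(Nc2ccc3nccc(-c4ccncc4)c3n2)c1`) gives 115000 nM, the only actual number among the measured compounds. Compound 1 (`NS(=O)(=O)c1cncc(-c2ccc3nccc(-c4cn[nH]c4)c3n2)c1`) gives < 5000 nM, which is a limit and not a number. Compound 2 (`O=S(=O)(c1cccc(Nc2ccc3nccc(-c4ccncc4)c3n2)c1)N1CCCC1`) gives < 5000 nM, also a limit. Compound 4 (`O=S(=O)(NCc1ccccc1)c1cccc(Nc2ccc3nccc(-c4ccncc4)c3n2)c1`) differs from compound 3 on a saturated chain carbon bound to a sulfonamide nitrogen: phenyl in place of hydroxymethyl on a saturated chain carbon bound to a sulfonamide nitrogen. Among the compounds with values here, the one measured step bearing on this change, an at least 23-fold higher number from compound 2 to compound 3 (1.36 log units; beyond the scatter), is large and also concerns the 2-hydroxyethyl group. Removing that group is therefore expected to give a large step to a lower number, with the expected change being a 29-fold lower number from compound 3 to compound 4 (1.46 log units; beyond the scatter). The estimate for compound 4 is 4000 nM, with an expected range of 1000 nM to 15000 nM.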

Compound 4, solubility: < 5000 nM
Compound 4: no number, only a limit (the forecaster's own chance of this, stated with the estimate: 70%); the middle value is on the limit's open side.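

In this assay, phenyl in place of hydroxymethyl on this saturated chain carbon gives an at least 23-fold lower number from compound 3 to compound 4 (1.36 log units; beyond the scatter), so a second replacement of the 2-hydroxyethyl group, after the pyrrolidine of compound 2, also loses the number of compound 3. Compound 4, like compound 2, gives only a limit and not a number: the limit of < 5000 nM in this assay, at which 3 of the 4 values shown sit.

The step between these two compounds cannot be read, so benzylamino and pyrrolidin-1-yl cannot be ranked. On these data alone, how far compound 4 lies under its limit remains open, as does whether an amine or a carboxylic acid at the end of the chain would give a number like that of compound 3.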